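The source may hold more compounds than are shown below. What is called first, only, known or untested is meant among the compounds shown, and "the series" means these compounds.

Compound 1 `Cc1cc(=O)c(O)c(C(=O)O)o1`: 27%
Compound 2 `Cc1cc(=O)c(O)c(C(N)=O)o1`: 35%

In an assay on isolated protein for inhibition of methionine aminopeptidase 2 (Homo sapiens), read by fluorescence, tested at 200 uM (on this read-out higher numbers stand for more inhibition at the one concentration tested (going by the name of the read-out) and lower numbers for less inhibition), compound 2 shows the larger of the two numbers, yet a number 8 percentage points higher from compound 1 to compound 2 (within the scatter) lies within the scatter, so the two compounds cannot be told apart. Compound 3 `CNC(=O)c1oc(C)cc(=O)c1O` differs from compound 2 by methyl in place of hydrogen on an amide-type nitrogen. Going by the values given here, no measured step touches the amide-type nitrogen; the only step known, a number 8 percentage points higher from compound 1 to compound 2 (within the scatter), altered the carbonyl carbon and stayed within the scatter. The step of no change at the digits printed from compound 2 to compound 3 (within the scatter) is therefore expected to remain within the scatter. Compound 3 is estimated at 35%, with a range from 20% to 50%.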

Compound 3, a percentage reported as inhibition, at one concentration (the size of the read-out at that concentration, not a potency): 24%
Estimate against measurement, compound 3: 11 percentage points above; low and high end bracket the measured number.
By their numbers in this assay, from the lowest: compounds 3, 1 and 2 (each within the scatter of the next, the first and the last beyond it).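

In this assay, methyl in place of hydrogen on the amide-type nitrogen gives a number 11 percentage points lower from compound 2 to compound 3 (beyond the scatter), the only step shown that passes the scatter, so the read-out does respond to a change at this nitrogen. Methylamino in place of hydroxy on the carbonyl carbon gives a number 3 percentage points lower from compound 1 to compound 3 (within the scatter), leaving compound 3 indistinguishable from compound 1. Nothing available explains the modest step from the amide hydrogen to methyl. The compounds shown leave open whether an ethyl group, a longer chain or a second methyl on this nitrogen would read the same way as methyl.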